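The compounds below may be only part of what the source reports. "The series", "measured", "known", "first", "only" and "open" are said of these compounds alone.

Measured so far:
compound 1 `C=C1CC[C@@H]2[C@](C)(CNCc3ccc(C)cc3)[C@H](O)CC[C@@]2(C)[C@@H]1/C=C/C1=CCOC1=O`, which in a functional assay on BMMC cells (Mus musculus, strain C57BL/6) for inhibition, with stated times of 5 days and 48 h (a higher number here means a weaker inhibitor, a lower number a stronger inhibitor), gives 740 nM;
compound 2 `C=C1CC[C@@H]2[C@](C)(CNCc3cccc(OC)c3)[C@H](O)CC[C@@]2(C)[C@@H]1/C=C/C1=CCOC1=O`, which in this assay gives 780 nM;
compound 3 `C=C1CC[C@@H]2[C@](C)(CNCc3ccc(F)cc3)[C@H](O)CC[C@@]2(C)[C@@H]1/C=C/C1=CCOC1=O`, which in this assay gives 350 nM.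

Compound 1 sits second highest of these three numbers. Its nearest neighbour is compound 2, with a 1.1-fold higher number from compound 1 to compound 2 (0.02 log units; within the scatter), and its furthest is compound 3, with a 2.1-fold lower number from compound 1 to compound 3 (0.33 log units; beyond the scatter). Compound 4 `C=C1CC[C@@H]2[C@](C)(CNCc3ccc([N+](=O)[O-])cc3)[C@H](O)CC[C@@]2(C)[C@@H]1/C=C/C1=CCOC1=O` has not yet been measured; it differs from compound 1 by nitro in place of methyl on an aromatic carbon.

Among the measured compounds shown here, the step that bears most directly on this is the one from compound 1 to compound 3, where another group replaced methyl on the same aromatic carbon and gave a 2.1-fold lower number from compound 1 to compound 3 (0.33 log units; beyond the scatter). The step from compound 2 to compound 3 points the same way, a 2.2-fold lower number from compound 2 to compound 3 (0.35 log units; beyond the scatter). Two of the three compounds are within scatter of one another, so the swing seen so far is modest. A step in this assay of similar modest size, lower, or none beyond the scatter, is expected for compound 4.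

Compound 4 is therefore estimated at 500 nM, between 200 nM and 1300 nM, which would mean a 1.5-fold lower number from compound 1 to compound 4 (0.17 log units; within the scatter).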

Compound 4, half-maximal inhibitory concentration: 1340 nM
Estimate against measurement, compound 4: 2.7-fold (0.43 log units) below; measured number outside the range, above it.
By their numbers in this assay, from the lowest: compound 3; then compounds 1, 2 and 4 (each within the scatter of the next).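

In this assay, nitro on this aromatic carbon cannot be told apart from methyl (a 1.8-fold higher number from compound 1 to compound 4 (0.26 log units; within the scatter)), even though nitro brings more heavy atoms and two hydrogen-bond acceptors. Compound 4 also stays within the scatter of the 3-methoxyphenyl compound (a 1.7-fold higher number from compound 2 to compound 4 (0.24 log units; within the scatter)), but replacing fluoro with nitro on the same carbon gives a step beyond it (a 3.8-fold higher number from compound 3 to compound 4 (0.58 log units; beyond the scatter)), so among these four compounds only the fluoro compound stands apart. No measurement shown here accounts for this difference.

Going by these compounds, whether an amine, a carboxylic acid or a longer chain on this carbon would fall with fluoro or with the other three groups remains open. So does how a plain phenyl ring, with only hydrogen at this carbon, would compare.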